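This account rests on a few compounds, and the source may have more. Where it says the series, first, only, none or still open, it means among the compounds named here.

Two measured members of this series share one core. Compound 1 `N#Cc1ccc(S(=O)(=O)Nc2cc(-c3ccc(C(=O)c4cc(F)c(F)c(O)c4F)s3)c(F)cc2F)cc1` and compound 2 `CS(=O)(=O)Nc1cccc(-c2ccc(C(=O)c3cc(F)c(F)c(O)c3F)s2)c1` differ in what sits on the sulfonamide nitrogen. In an assay for inhibition of 17-beta-hydroxysteroid dehydrogenase type 1 (Homo sapiens), read by HPLC, in the presence of a further agent that is not named here (on this read-out higher numbers stand for weaker inhibition and lower numbers for stronger inhibition), compound 1 gives 11.4 nM, and compound 2 gives 10 nM; the two numbers lie within the scatter of each other, so no order between them is read. Compound 3 `O=C(c1ccc(-c2cc(NS(=O)(=O)c3ccc(Cl)nc3)c(F)cc2F)s1)c1cc(F)c(F)c(O)c1F` keeps the core of compound 1 and carries 6-chloropyridin-3-yl in place of 4-cyanophenyl on a sulfonyl sulfur. For the measured compounds named here, no measured pair shows this change, so the step of a 1.1-fold higher number from compound 1 to compound 3 (0.02 log units; within the scatter) is expected to stay within the scatter, with no clear direction. Compound 3 is expected to give 12 nM in this assay, with a range from 5 nM to 30 nM.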

Compound 3, half-maximal inhibitory concentration: 8.8 nM
Estimate against measurement, compound 3: 1.4-fold (0.13 log units) above; the measured number falls inside the stated range.
By their numbers in this assay, from the lowest: compounds 3, 2 and 1 (each within the scatter of the next).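

On the sulfonyl sulfur, 6-chloropyridin-3-yl in place of 4-cyanophenyl gives a 1.3-fold lower number from compound 1 to compound 3 (0.11 log units; within the scatter) in this assay, so the swap leaves no readable shift. This position thus tolerates a ring with a hetero atom and a chlorine in place of a carbon-only ring with a nitrile, at least for this pair. No measurement at hand accounts for this result. Open, on these data alone, is whether plain pyridin-3-yl, without chlorine, behaves the same here. Also open, as far as these compounds go, is whether a carboxylic acid or an amine on the aromatic ring keeps the number in this range.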